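The source may report more compounds than this note shows. Statements on the series, on what has been measured and on what is new or still open speak of the compounds shown alone.

Measured so far in an assay on THP-1 cells for antagonist activity at P2X purinoceptor 7 (Homo sapiens), read by ELISA, with a stated time of 30 min; a lower number here means a stronger inhibitor, a higher number a weaker inhibitor:
- compound 1 `O=C(c1ccc(Cl)c(C(F)(F)F)c1)N1CCC(n2cncc2-c2ccc(OS(=O)(=O)c3cccc4cnccc34)cc2)CC1`: compound 1 gives 22 nM
- compound 2 `CN(C)c1ccc(C(=O)N2CCC(n3cncc3-c3ccc(OS(=O)(=O)c4cccc5cnccc45)cc3)CC2)cc1`: compound 2 gives 2.19 nM
- compound 3 `CC(C)(O)c1ccc(C(=O)N2CCC(n3cncc3-c3ccc(OS(=O)(=O)c4cccc5cnccc45)cc3)CC2)cc1`: compound 3 gives 4.7 nM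

Compound 2 has the lowest number of the three in this assay. Its nearest neighbour is compound 3, reached by a 2.1-fold higher number from compound 2 to compound 3 (0.33 log units; beyond the scatter); the widest gap is to compound 1, covered by a 10-fold lower number from compound 1 to compound 2 (1.00 log units; beyond the scatter).

Compound 4 `CNC(=O)c1cccc(S(=O)(=O)Oc2ccc(-c3cncn3C3CCN(C(=O)c4ccc(N(C)C)cc4)CC3)cc2)c1` differs from compound 2 in one place: 3-(methylcarbamoyl)phenyl in place of isoquinolin-5-yl on a sulfonyl sulfur. Every measured step in the set, a 10-fold lower number from compound 1 to compound 2 (1.00 log units; beyond the scatter), a 4.7-fold lower number from compound 1 to compound 3 (0.67 log units; beyond the scatter) and a 2.1-fold higher number from compound 2 to compound 3 (0.33 log units; beyond the scatter), concerns the group on the carbonyl carbon and leaves the sulfonyl side untouched, so none of them bears directly on this change. The sulfonyl substituent is held constant across compounds 1 to 3, which only shows that the series tolerates variation elsewhere while this part is kept. With no comparison to lean on, the expectation for compound 4 is a step that is modest at most, in either direction; a small loss is taken as the central guess, the step of a 2.7-fold higher number from compound 2 to compound 4 (0.44 log units; beyond the scatter) being expected. Compound 4 is therefore estimated at 6 nM in this assay, with a range from 1.5 nM to 30 nM.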

Compound 4, half-maximal inhibitory concentration: 22 nM
For compound 4 the middle estimate is 3.7-fold (0.56 log units) below the measured one, and the stated range covers the measured number.
By their numbers in this assay, from the lowest: compound 2; then compound 3; then compounds 1 and 4 (each within the scatter of the next).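

The sulfonyl sulfur substituent, constant through compounds 1 to 3, is now shown to affect potency: in this assay, 3-(methylcarbamoyl)phenyl in place of isoquinolin-5-yl gives a 10-fold higher number from compound 2 to compound 4 (1.00 log units; beyond the scatter). This one change on the sulfonyl side moves the number by as much as the change on the carbonyl side does in the opposite direction (a 10-fold lower number from compound 1 to compound 2 (1.00 log units; beyond the scatter)), so potency responds to changes on both sides of the shared core. Nothing available explains the loss on the sulfonyl side.

A single replacement cannot separate the removal of isoquinolin-5-yl from the introduction of the methylcarbamoyl group. Open, from the compounds shown here alone, is whether a plain phenyl or a naphthyl on the sulfonyl sulfur would keep the number of compound 2 or follow compound 4.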